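Azaindole isomer swap in the cathepsin S series

The source may report more compounds than this note shows. Statements on the series, on what has been measured and on what is new or still open speak of the compounds shown alone.

Measured compounds:
- compound 1, `Cn1c(=O)n(C2CCN(CCCn3nc(-c4ccc(Cl)c(Cl)c4)c4c3CCN(S(C)(=O)=O)C4)CC2)c2ccccc21`: 800 nM
- compound 2, `CCOC(=O)c1ccc2[nH]cc(C3CCN(CC(O)Cn4nc(-c5ccc(C(F)(F)F)cc5)c5c4CCN(S(C)(=O)=O)C5)CC3)c2c1`: 410 nM
- compound 3, `CS(=O)(=O)N1CCc2c(c(-c3ccc(C(F)(F)F)cc3)nn2CC(O)CN2CCC(c3c[nH]c4cccnc34)CC2)C1`: 95 nM

All three were tested in an assay on JY cells for inhibition of cathepsin S (Homo sapiens); a lower number here means a stronger inhibitor, a higher number a weaker inhibitor. On these numbers compound 3 has the lowest value of the three; compound 2 is the nearest and compound 1 the furthest, and both gaps lie beyond the scatter, so compound 3 is the strongest inhibitor of the three measured.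

Compound 4, `CS(=O)(=O)N1CCc2c(c(-c3ccc(C(F)(F)F)cc3)nn2CC(O)CN2CCC(c3c[nH]c4ccncc34)CC2)C1`, has not been measured. It shares the same atoms as compound 3, joined differently: the change is a group of 9 heavy atoms (7 carbon, 2 nitrogen; one five-membered aromatic ring with 1 hetero atom, one six-membered aromatic ring with 1 hetero atom) in place of a group of 9 heavy atoms (7 carbon, 2 nitrogen; one five-membered aromatic ring with 1 hetero atom, one six-membered aromatic ring with 1 hetero atom), on a saturated ring carbon. In words, a group of 9 heavy atoms (7 carbon, 2 nitrogen; one five-membered aromatic ring with 1 hetero atom, one six-membered aromatic ring with 1 hetero atom) in place of a group of 9 heavy atoms (7 carbon, 2 nitrogen; one five-membered aromatic ring with 1 hetero atom, one six-membered aromatic ring with 1 hetero atom), on a saturated ring carbon.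

Going by the values given here, no pair among the measured compounds differs in just this one place, so the size of this step has no precedent in the set. The bicyclic group keeps its donor and acceptor count, and the rest of the molecule is unchanged; the expected step is small, with no clear direction, and is estimated as a 1.6-fold higher number from compound 3 to compound 4 (0.20 log units; within the scatter), likely within the scatter. Compound 4 is expected to give 150 nM in this assay, within a range of 50 nM to 450 nM.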

Compound 4, half-maximal inhibitory concentration: 25 nM
For compound 4 the middle estimate is 6.0-fold (0.78 log units) above the measured one; the measured number lies below the stated range.
By their numbers in this assay, from the lowest: compound 4; then compound 3; then compounds 2 and 1 (each within the scatter of the next).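

In this assay, going by these compounds alone, the bicyclic group on the saturated ring carbon of the piperidine-type ring, three ring bonds from the ring nitrogen, proves sensitive to how its atoms are joined: the swap gives a 3.8-fold lower number from compound 3 to compound 4 (0.58 log units; beyond the scatter) and is the first single-place step. The leaving and entering groups have the same heavy atoms, the same hydrogen-bond donor and acceptor counts and no net charge, so this position responds to connectivity alone, with composition held fixed. Nothing available explains why this arrangement of the bicyclic group gives the lower number.

Still open, as far as these compounds go, is whether other changes to the group at this position, such as a methyl, a fluorine or a methoxy on the bicyclic group, would move the number further from that of compound 4. From the compounds shown here alone, it is also open whether the same swap keeps its size on the core of compound 1, which carries a different chain and aryl group, or only on the core shared by compound 3 and compound 4.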